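Swapping phenyl for piperidine to lift solubility

A few compounds are considered here, and "the series" means these few. Any claim that something is new, unique, unknown or untested is made for them only; others in the source may bear on it.

Four compounds from one series are compared for how well they dissolve, read as a physicochemical assay for solubility, read by HPLC; on this read-out lower numbers stand for lower solubility and higher numbers for higher solubility. Compound 1 `Cn1nc(N)c2c(=O)[nH]c(-c3ccccc3)cc21` carries a phenyl on its core, and in this assay compound 1 gives 76 ug/mL. Compound 2 `Cn1nc(N)c2c(=O)[nH]c(C3CCNCC3)cc21` carries a piperidin-4-yl at that position instead. In this assay compound 2 reaches only a limit of the method, > 15000 ug/mL, so its true value is not known as a number. The change from compound 1 to compound 2, (piperidin-4-yl in place of phenyl on an aromatic carbon), brings an at least 190-fold higher number from compound 1 to compound 2 (2.29 log units; beyond the scatter); since the read-out stops at the limit of > 15000 ug/mL in this assay, at which 1 of the 3 values shown sits, the step is at least this size.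

Compound 3 `Nc1c2c(=O)[nH]c(-c3ccccc3)cc2nn1-c1ccccc1` has a different core, and how it differs from the core of compound 1 is not broken down here. In this assay compound 3 gives only a limit, < 1 ug/mL, not a number. Compound 4 `Nc1c2c(=O)[nH]c(C3CCNCC3)cc2nn1-c1ccccc1` has not yet been measured. It differs from compound 3 by piperidin-4-yl in place of phenyl on an aromatic carbon, which is the same change as that between compound 1 and compound 2, made at the same place.

For compound 4 a large rise over compound 3 is therefore expected, resting on an at least 190-fold higher number from compound 1 to compound 2 (2.29 log units; beyond the scatter), though because compound 3 sits at the limit of < 1 ug/mL in this assay, at which 1 of the 3 values shown sits, the starting point is itself not a number. For compound 4 the expected step is an at least 200-fold higher number from compound 3 to compound 4 (2.30 log units; beyond the scatter). In this assay compound 4 is estimated at 200 ug/mL, plausibly between 20 ug/mL and 2000 ug/mL.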

Compound 4, solubility: 1430 ug/mL
The estimate for compound 4 lay 7.2-fold (0.85 log units) below the measured number; measured number inside the range.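

The same swap of piperidin-4-yl for phenyl, carried to a second core, gives an at least 1400-fold higher number from compound 3 to compound 4 (3.15 log units; beyond the scatter) in this assay, and this matches the direction and large size of the step on the first core, an at least 190-fold higher number from compound 1 to compound 2 (2.29 log units; beyond the scatter). On these data alone, compound 3 stands at a limit and not at a number, so the true size of the new step stays unknown: the limit of < 1 ug/mL in this assay, at which 1 of the 4 values shown sits. Compound 2 also stands at a limit, so the two steps cannot be ranked by size, and agreement on two cores does not promise the same result on a third: the limit of > 15000 ug/mL in this assay, at which 1 of the 4 values shown sits.

The compounds shown leave open which part of the change goes with the rise: the entering ring is non-aromatic and also holds a nitrogen, and a cyclohexyl group, with a non-aromatic ring of carbon only, or a tetrahydropyran-4-yl group, with oxygen in place of that nitrogen, would pull these two features apart. They also leave open how a 1-methylpiperidin-4-yl group, or an open chain ending in an amine, would compare with piperidin-4-yl on either core.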